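Compound 2 to compound 3: a fluoro exchange

The source may report more compounds than this note shows. Statements on the series, on what has been measured and on what is new or still open speak of the compounds shown alone.

Among the compounds with values here, in a functional assay on SK-OV-3 cells (Homo sapiens) (a lower number here means a stronger inhibitor of growth, a higher number a weaker inhibitor of growth), compound 2 (`O=S(=O)(/C=C/c1ccc(F)cc1F)Cc1ccc(Nc2ncnc3ccccc23)cc1`) gives 69000 nM, the only true number in this small series. Compound 1 (`N#Cc1ccc(/C=C/S(=O)(=O)Cc2ccc(Nc3ncnc4ccccc34)cc2)cc1`) reads > 100000 nM, which is a limit of the assay and not a number. The series therefore sits close to the limit of > 100000 nM in this assay, at which 1 of the 2 values shown sits.

Compound 3 (`O=S(=O)(/C=C/c1ccc(C(F)(F)F)cc1F)Cc1ccc(Nc2ncnc3ccccc23)cc1`) differs from compound 2 by trifluoromethyl in place of fluoro on an aromatic carbon. In words, trifluoromethyl stands in place of fluoro on an aromatic carbon, para to a large group, so that 2,4-difluorophenyl becomes 2-fluoro-4-(trifluoromethyl)phenyl.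

Within the data shown here, only one measured step bears on this change: an at least 1.4-fold lower number from compound 1 to compound 2 (0.16 log units; that floor lies within the scatter), with 2,4-difluorophenyl in place of 4-cyanophenyl. That step rests on a limit and gives no direction for the new exchange, so no shift beyond the scatter is expected in this assay. The estimated change is a 1.0-fold higher number from compound 2 to compound 3 (0.01 log units; within the scatter). For compound 3 the expected value is 70000 nM, with an estimated range from 35000 nM to 130000 nM.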

Compound 3, concentration for 50% growth inhibition: 39000 nM
Compound 3: the middle estimate sits 1.8-fold (0.25 log units) above what was measured; low and high end bracket the measured number.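

Trifluoromethyl in place of fluoro, on an aromatic carbon para to a large group, gives the first comparison in this series between two true numbers in this assay and reads a 1.8-fold lower number from compound 2 to compound 3 (0.25 log units; within the scatter) with 4 heavy atoms entering where 1 leaves, so this position accepts the larger group without a readable change. Compound 1 reads > 100000 nM here, which is a limit of the assay and not a number. Set against that limit, 2-fluoro-4-(trifluoromethyl)phenyl in place of 4-cyanophenyl gives an at least 2.5-fold lower number from compound 1 to compound 3 (0.40 log units; beyond the scatter) as the only step shown that lies beyond the scatter, while the series as a whole stays close to the limit: the limit of > 100000 nM in this assay, at which 1 of the 3 values shown sits.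

Open, on these data alone, is whether the flat reading between fluoro and trifluoromethyl holds for a different kind of group at this position, such as an amine or a carboxylic acid. Also open, as far as these compounds go, is what the remaining fluoro group contributes, which an exchange for hydrogen or methoxy would show, and whether any such change moves growth inhibition well away from the limit.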